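The compounds below may be only part of what the source reports. "The series", "measured", "known", "first", "only" and "open" are said of these compounds alone.

Of the compounds shown here, three have been measured in an assay on isolated protein for inhibition of Amine oxidase [flavin-containing] A (Homo sapiens), read by fluorescence, with a stated time of 30 min; a lower number here means a stronger inhibitor, a higher number a weaker inhibitor: compound 1 `CCN(CCCCn1sc2cc(OC)c(OC)cc2c1=O)Cc1ccccc1OC` gives 9600 nM, compound 2 `COc1cc2sn(CCCCCCN(C)Cc3ccccc3)c(=O)c2cc1OC` gives 23000 nM, and compound 3 `CCN(CCCCCCn1sc2cc(OC)c(OC)cc2c1=O)Cc1ccccc1` gives 8200 nM.

Compound 3 holds the lowest of the three numbers shown, though compound 1 lies within the scatter of it and only compound 2 lies beyond. Going by the values given here, the single step between measured compounds, a 2.8-fold lower number from compound 2 to compound 3 (0.45 log units; beyond the scatter), concerns the saturated chain and not the aromatic ring. Compound 4 `CCN(CCCCCCn1sc2cc(OC)c(OC)cc2c1=O)Cc1ccccc1N(C)C` differs from compound 3 in dimethylamino in place of hydrogen on an aromatic carbon. Among the compounds with values here, no measured step bears on this change; compound 1 and compound 3, which differ in more than one place, give values within the scatter of each other. The expected step of a 1.0-fold lower number from compound 3 to compound 4 (0.01 log units; within the scatter) is therefore none beyond the scatter. Compound 4 is estimated at 8000 nM, within 3000 nM to 25000 nM.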

Compound 4, half-maximal inhibitory concentration: 3400 nM
Estimate against measurement, compound 4: 2.4-fold (0.37 log units) above, within the range that was stated.
By their numbers in this assay, from the lowest: compound 4; then compounds 3 and 1 (each within the scatter of the next); then compound 2.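

Dimethylamino on an aromatic carbon, ortho to a large group, gives the first one-place reading on this aromatic ring in this assay: the change brings a 2.4-fold lower number from compound 3 to compound 4 (0.38 log units; beyond the scatter). The earlier step concerned only the saturated chain, so this one shows that the number also moves with a change at this ring position. Nothing at hand gives a reason for the step. From the compounds shown here alone, whether amino, morpholine or a carboxylic acid on this carbon would give a step of similar size remains open. So does whether dimethylamino would give the same step on the chain of compound 1.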